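Cytotoxicity in the thiourea series: furan-2-yl for phenethyl

This account rests on a few compounds, and the source may have more. Where it says the series, first, only, none or still open, it means among the compounds named here.

Compound 3 `O=C(CCc1ccccc1)NC(=S)N1CCc2c(OCCCCCOc3ccc(Cl)cc3)cccc21` stands at the upper edge of what has been measured in an ADME assay on Huh-7 cells (Homo sapiens) for cytotoxicity; a higher number here means that more compound is tolerated, a lower number that less compound is tolerated: compound 3 gives > 50000 nM, which is a limit of the assay and not a number. Compound 2 `CN(C)c1ccc(C(=O)NC(=S)N2CCc3c(OCCCCCOc4ccc(Cl)cc4)cccc32)cc1` likewise gives a limit, > 50000 nM. Compound 1 `O=C(NC(=S)N1CCc2c(OCCCCCOc3ccc(Cl)cc3)cccc21)c1ccc(Cl)cc1` gives 21700 nM. The steps of an at least 2.3-fold higher number from compound 1 to compound 2 (0.36 log units; beyond the scatter) and an at least 2.3-fold higher number from compound 1 to compound 3 (0.36 log units; beyond the scatter) both move the number past the limit; the step that the two limits leave unreadable from compound 2 to compound 3 cannot be sized because both ends sit at the limit of > 50000 nM in this assay, at which 2 of the 3 values shown sit.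

Compound 4 `O=C(NC(=S)N1CCc2c(OCCCCCOc3ccc(Cl)cc3)cccc21)c1ccco1` differs from compound 3 by furan-2-yl in place of phenethyl on a carbonyl carbon. Among the compounds with values here, the only step that bears on this place is an at least 2.3-fold higher number from compound 1 to compound 3 (0.36 log units; beyond the scatter), where an aryl group directly on the carbonyl carbon was exchanged for phenethyl and the number rose beyond the scatter. Compound 4 returns an aromatic ring to the carbonyl carbon, so compound 4 is expected to give a lower number than compound 3, estimated at 30000 nM within 14000 nM to 60000 nM. The expected step is therefore an at least 1.6-fold lower number from compound 3 to compound 4 (0.22 log units; that floor lies within the scatter), though a second limit would not be surprising.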

Compound 4, half-maximal cytotoxic concentration: 4620 nM
Beside the measured number, compound 4's estimate is 6.5-fold (0.81 log units) above it; measured number below the stated range.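

In this assay, furan-2-yl in place of 4-chlorophenyl gives a 4.7-fold lower number from compound 1 to compound 4 (0.67 log units; beyond the scatter), so the two aromatic groups on the carbonyl carbon are not interchangeable. The same group gives an at least 10-fold lower number from compound 3 to compound 4 (1.03 log units; beyond the scatter) in place of phenethyl and an at least 10-fold lower number from compound 2 to compound 4 (1.03 log units; beyond the scatter) in place of 4-(dimethylamino)phenyl. Compound 4 now has the lowest number of the four, so an aromatic ring on the carbonyl carbon does not by itself bring the number down, and compound 2, which carries such a ring, goes against any such rule.

The compounds shown do not separate the ring oxygen of furan-2-yl from the five-membered ring size, a question on which thiophen-2-yl or unsubstituted phenyl at this place would bear. The step from compound 2 to compound 3 cannot be read: the limit of > 50000 nM in this assay, at which 2 of the 4 values shown sit.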